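From 4-hydroxyphenyl to 4-hydroxybenzyl on the amide

The compounds below may be only part of what the source reports. "The series", "measured", "known", "first", "only" and "open" are said of these compounds alone.

In a functional assay on MCF7 cells (Homo sapiens) for inhibition, read by MTT assay (on this read-out lower numbers stand for stronger inhibition of growth and higher numbers for weaker inhibition of growth), compound 1 (`CC1=C(/C=C/C(C)=C/C=C/C(C)=C\C(=O)Nc2ccc(O)cc2)C(C)(C)CCC1n1ccnc1`) gives 1990 nM. Compound 2 (`CC1=C(/C=C/C(C)=C/C=C/C(C)=C\C(=O)NCc2cccc(F)c2)C(C)(C)CCC1n1ccnc1`) gives 1810 nM, which lies within the scatter of compound 1. Compound 3 (`CC1=C(/C=C/C(C)=C/C=C/C(C)=C\C(=O)Nc2ccccc2)C(C)(C)CC=C1c1cncnc1`) gives 7010 nM, a clearly higher number than either of the other two. Compound 1 therefore sits level with compound 2, at the low end of the three numbers, and well away from compound 3.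

The unmeasured compound 4 (`CC1=C(/C=C/C(C)=C/C=C/C(C)=C\C(=O)NCc2ccc(O)cc2)C(C)(C)CCC1n1ccnc1`) carries 4-hydroxybenzyl in place of 4-hydroxyphenyl on an amide-type nitrogen.

For the measured compounds named here, only one measured step bears on this change. Putting 3-fluorobenzyl in place of 4-hydroxyphenyl on the same nitrogen gave a 1.1-fold lower number from compound 1 to compound 2 (0.04 log units; within the scatter). Going by the values given here, no measured compound carries 4-hydroxybenzyl itself, so this single pair is limited support. On the strength of that one step, no change beyond the scatter is expected in this assay, and neither direction is favoured. The estimated step is a 1.0-fold lower number from compound 1 to compound 4 (0.02 log units; within the scatter). Compound 4 is expected to give about 1900 nM, with an estimated range of 850 nM to 4200 nM.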

Compound 4, concentration for 50% growth inhibition: 160 nM
For compound 4 the middle estimate is 12-fold (1.07 log units) above the measured one, outside the stated range (below it).
By their numbers in this assay, from the lowest: compound 4; then compounds 2 and 1 (each within the scatter of the next); then compound 3.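

For the compounds shown here, the amide-type nitrogen turns out to be far more sensitive in this assay than the earlier compounds suggested: 4-hydroxybenzyl in place of 4-hydroxyphenyl gives a 12-fold lower number from compound 1 to compound 4 (1.09 log units; beyond the scatter) and marks compound 4 as the one clear outlier at the low end of the series. The saturated chain carbon bound to that nitrogen is not enough on its own, since compound 2 carries it too and still lies within the scatter of compound 1. With that carbon kept, the step to 4-hydroxyphenyl in place of 3-fluorophenyl is an 11-fold lower number from compound 2 to compound 4 (1.05 log units; beyond the scatter) and is about as large as the first, so the large gain appears only where the chain carbon and the 4-hydroxyphenyl occur together.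

The compounds shown leave open whether the gain survives with a 4-aminobenzyl group on the same nitrogen, or with a longer chain between that nitrogen and the 4-hydroxyphenyl. Nothing available here explains why this one change has so large an effect on growth inhibition.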